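This account rests on a few compounds, and the source may have more. Where it says the series, first, only, none or still open, it means among the compounds named here.

Notes on the hydroxybenzamide series. Compound 1 `O=C(Nc1cccc(C(F)(F)F)c1F)c1cc(Cl)ccc1O` gives 5300 nM in an ADME assay on cells (Macrophage, Mus musculus) for cytotoxicity, read by resazurin assay, with a stated time of 3 days; on this read-out lower numbers stand for stronger inhibition and higher numbers for weaker inhibition. Compound 2 `O=C(Nc1cccc(F)c1F)c1cc(Cl)ccc1O` gives 13000 nM in this assay, and compound 3 `O=C(Nc1ccc(F)cc1C(F)(F)F)c1cc(Cl)ccc1O` gives 13000 nM in this assay. The change fluoro in place of trifluoromethyl on an aromatic carbon made a 2.5-fold higher number from compound 1 to compound 2 (0.39 log units; beyond the scatter). Compound 3 stands level with compound 2 at the digits given; together they carry the highest numbers of the three, and compound 3 sits at a higher number than compound 1. Compound 3 and compound 1 hold the same atoms joined differently; the difference between the two cores is not broken down here.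

Compound 4 `O=C(Nc1ccc(F)cc1F)c1cc(Cl)ccc1O` is still to be measured in this assay. It relates to compound 3 by fluoro in place of trifluoromethyl on an aromatic carbon. This is the same kind of change as from compound 1 to compound 2, not the same: here the carbon sits ortho to a large group and meta to a fluoro group, whereas from compound 1 to compound 2 it sits ortho to a fluoro group and meta to a large group. A step of a 2.2-fold higher number from compound 3 to compound 4 (0.33 log units; beyond the scatter) is expected, resting on a 2.5-fold higher number from compound 1 to compound 2 (0.39 log units; beyond the scatter) in the earlier pair. Compound 4 is estimated at 28000 nM, expected to fall between 12000 nM and 60000 nM.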

Compound 4, half-maximal inhibitory concentration: 8500 nM
Compound 4: the middle estimate sits 3.3-fold (0.52 log units) above what was measured; the whole stated range lies above it.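

In this assay, fluoro in place of trifluoromethyl gives a 1.5-fold lower number from compound 3 to compound 4 (0.18 log units; within the scatter), so on the core of compound 3 this change yields no difference that can be told from the scatter. The change therefore does not carry over at the size seen from compound 1 to compound 2, and the two steps differ: the same change on two cores in this assay, a 2.5-fold higher number (0.39 log units; beyond the scatter) from compound 1 to compound 2 and a 1.5-fold lower number (0.18 log units; within the scatter) from compound 3 to compound 4, 3.8-fold (0.57 log units) apart, beyond the scatter of two such steps. This rests on a single pair for each core, so it shows that the step cannot be assumed to transfer between these two cores, but it does not show why the steps part or how the change would read on any further core.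

Across the compounds shown, the varied groups are only fluoro and trifluoromethyl, so it stays open how a nitrile, a methoxy group or an amine in the same place would read in this assay. Also open, as far as these compounds go, is whether a third core would follow the step of either pair.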